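Ethyl to Methyl: One Shortening, Two Settings

The compounds below may be only part of what the source reports. "The series", "measured", "known", "first", "only" and "open" are said of these compounds alone.

Compound 1 `Cc1ccc2nc(C(=O)Nc3c(F)cc(-c4cccc(F)c4)cc3F)c(C)c(O)c2c1` gives 25.5% in a functional assay on Hep 3B2 cells (Homo sapiens) for antiproliferative activity, read by MTT assay, with a stated time of 24 h, tested at 11.11 ug/mL; on this read-out lower numbers stand for a weaker effect and higher numbers for a stronger effect at the one concentration tested. Compound 2 `CCc1ccc2nc(C(=O)Nc3c(F)cc(-c4cccc(F)c4)cc3F)c(C)c(O)c2c1` gives 46.3%. Compound 3 `CCOc1ccc2nc(C(=O)Nc3c(F)cc(-c4cccc(F)c4)cc3F)c(C)c(C(=O)O)c2c1` gives 33.2%.

Compound 4 `COc1ccc2nc(C(=O)Nc3c(F)cc(-c4cccc(F)c4)cc3F)c(C)c(C(=O)O)c2c1` has not been measured. It differs from compound 3 by hydrogen in place of methyl on a saturated chain carbon bound to an oxygen on an aromatic ring. The same kind of change, (hydrogen in place of methyl on a saturated chain carbon bound to an aromatic carbon), is seen between two measured compounds, and there it made a number 20.8 percentage points lower from compound 2 to compound 1 (beyond the scatter). The two settings are not the same: in one the saturated chain carbon is bound to an aromatic carbon, in the other to an oxygen on an aromatic ring. How the core of compound 2 differs from that of compound 3 is not broken down here. Resting on the measured step from compound 2 to compound 1, the step from compound 3 to compound 4 is expected to be about a number 13.2 percentage points lower from compound 3 to compound 4 (beyond the scatter), tempered by the differing place. Compound 4 is therefore estimated at 20%.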

Compound 4, a percentage reported as inhibition, at one concentration (the size of the read-out at that concentration, not a potency): 2.34%
Compound 4: the middle estimate sits 17.7 percentage points above what was measured; measured number below the stated range.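

In this assay, shortening ethoxy to methoxy gave a number 30.9 percentage points lower from compound 3 to compound 4 (beyond the scatter), so the number fell on this core as it did when ethyl was shortened to methyl on the other. Set side by side, the two steps run in the same direction and cannot be told apart in size: the same change on two cores in this assay, a number 20.8 percentage points lower (beyond the scatter) from compound 2 to compound 1 and a number 30.9 percentage points lower (beyond the scatter) from compound 3 to compound 4, 10.1 percentage points apart, within the scatter of two such steps This rests on only two pairs, with the change in two different places and at a single concentration, so it does not show that the change would carry to any further core, nor why the number falls.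

The compounds shown leave open what a longer chain, such as propyl or propoxy, would do in the same place. They also leave open how an amine there would compare.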